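Swapping Benzyl for Bromophenylsulfonyl on the Core Nitrogen

A few compounds are considered here, and "the series" means these few. Any claim that something is new, unique, unknown or untested is made for them only; others in the source may bear on it.

Compound 1 `COc1ccc(-c2cc(=O)c3c(OC)cc(OC)cc3n2Cc2ccccc2)cc1`: in a functional assay on HepG2 cells (Homo sapiens) for antiproliferative activity, with a stated time of 72 h (a higher number here means that more compound is needed for the effect, a lower number that less compound is needed), compound 1 gives > 17300 nM, which is a limit of the assay and not a number.
Compound 2 `COc1ccc(-c2cc(=O)c3c(OC)cc(OC)cc3n2S(=O)(=O)c2ccc([N+](=O)[O-])cc2)cc1`: in this assay compound 2 gives > 29300 nM, again a limit of the assay.
Compound 3 `COc1ccc(-c2cc(=O)c3c(OC)cc(OC)cc3n2S(=O)(=O)c2cc(F)c(F)c(F)c2)cc1`: in this assay compound 3 gives > 65500 nM, also a limit of the assay.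

Compound 1 therefore stands at a limit, (the limit of > 17300 nM in this assay, at which 1 of the 3 values shown sits), and the two other values are limits as well. Compound 4 `COc1ccc(-c2cc(=O)c3c(OC)cc(OC)cc3n2S(=O)(=O)c2ccc(Br)cc2)cc1` has not been measured. It differs from compound 1 in one place: (4-bromophenyl)sulfonyl in place of benzyl on an aromatic nitrogen. Within the data shown here, only one measured step exists, a step that the two limits leave unreadable from compound 2 to compound 3, and it cannot be read because both ends are limits. Compounds 2 and 3, which also carry a sulfonyl group on that nitrogen, sit at the limit of > 29300 nM in this assay, at which 1 of the 3 values shown sits, and (the limit of > 65500 nM in this assay, at which 1 of the 3 values shown sits), so nothing suggests that a sulfonyl group there brings the value down into the measurable range. The step that the limit leaves unreadable from compound 1 to compound 4 is therefore expected to stay within the scatter, with the outcome most likely another limit. For compound 4 the estimated value in this assay is 50000 nM, with a range from 10000 nM to 200000 nM.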

Compound 4, half-maximal effective concentration: 16300 nM
The estimate for compound 4 lay 3.1-fold (0.49 log units) above the measured number; low and high end bracket the measured number.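

In this assay only compound 4 gives a true number rather than a limit, which shows that a sulfonyl group on this aromatic nitrogen can reach the measurable range when it carries 4-bromophenyl. The group on the sulfonyl sulfur counts, with an at least 4.0-fold lower number from compound 3 to compound 4 (0.60 log units; beyond the scatter) as a step beyond the scatter. From the compounds shown here alone, the other two steps, an at least 1.0-fold lower number from compound 1 to compound 4 (0.02 log units; that floor lies within the scatter) and an at least 1.7-fold lower number from compound 2 to compound 4 (0.25 log units; that floor lies within the scatter), are only floors within the scatter, so the true size of each stays unknown, as the other end of each is a limit.

Going by these compounds, whether bromo itself is needed on that aromatic carbon stays open, as chloro, an amine or a carboxylic acid in its place would test. Whether a sulfonyl group without an aromatic ring, such as methylsulfonyl, would give a number is open too.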